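The compounds below may be only part of what the source reports. "The series", "measured", "known", "first", "only" and "open" are said of these compounds alone.

Working notes on the series. Compound 1 `CN(C)CCn1cnnc1-c1cc(Oc2ccc(NC(=O)N/N=C/c3c(Cl)cccc3Cl)cc2F)ccn1` carries the 2,6-dichlorophenyl on the carbon with a double bond to nitrogen. In a functional assay on NCI-H460 cells (Homo sapiens) for cytotoxicity, read by MTT assay, with a stated time of 72 h (a higher number here means a weaker inhibitor, a lower number a stronger inhibitor), compound 1 gives 350 nM, the lowest of the three numbers recorded so far, though compound 2 lies within the scatter of it. Compound 2 `CN(C)CCn1cnnc1-c1cc(Oc2ccc(NC(=O)N/N=C/c3cc(C(C)(C)C)cc(C(C)(C)C)c3O)cc2F)ccn1` gives 590 nM in this assay. Within the data shown here, compound 3 `COc1ccc(/C=N/NC(=O)Nc2ccc(Oc3ccnc(-c4nncn4CCN(C)C)c3)c(F)c2)c(OC)c1` gives 1570 nM in this assay; the step of a 4.5-fold higher number from compound 1 to compound 3 (0.65 log units; beyond the scatter) is the only measured single change at this position, and it lies beyond the scatter.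

Compound 4 `CN(C)CCn1cnnc1-c1cc(Oc2ccc(NC(=O)N/N=C/c3ccc(O)c(Br)c3)cc2F)ccn1` has not yet been measured. It differs from compound 1 in one place: 3-bromo-4-hydroxyphenyl in place of 2,6-dichlorophenyl on a carbon with a double bond to nitrogen. Among the measured compounds shown here, the one measured step bearing on this position, a 4.5-fold higher number from compound 1 to compound 3 (0.65 log units; beyond the scatter), points towards a higher number when the 2,6-dichlorophenyl is exchanged. For the measured compounds named here, compound 2, whose aryl group at the same place also differs from that of compound 1, stays within the scatter of compound 1, but no single step between compound 1 and compound 2 has been worked out. For compound 4 a modest increase is therefore expected, a 2.0-fold higher number from compound 1 to compound 4 (0.30 log units; within the scatter). This expected step is smaller than the measured step to compound 3 and may fall within the scatter. The estimate for compound 4 in this assay is 700 nM, with a range from 250 nM to 2000 nM.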

Compound 4, half-maximal inhibitory concentration: 430 nM
For compound 4 the middle estimate is 1.6-fold (0.21 log units) above the measured one, within the range that was stated.
By their numbers in this assay, from the lowest: compounds 1, 4 and 2 (each within the scatter of the next); then compound 3.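

In this assay the step of a 1.2-fold higher number from compound 1 to compound 4 (0.09 log units; within the scatter) lies within the scatter, so the higher number seen at compound 3 does not follow from every exchange of the 2,6-dichlorophenyl on the carbon with a double bond to nitrogen; 3-bromo-4-hydroxyphenyl, which adds a hydrogen-bond donor and a hydrogen-bond acceptor to the count, gives no readable change from it. The second new comparison, a 3.7-fold lower number from compound 3 to compound 4 (0.56 log units; beyond the scatter), lies beyond the scatter and shows that two substituted phenyl groups at this same place can give clearly separated numbers, so the outcome here depends on which substituents the ring carries, at least across compounds 1, 3 and 4. No accompanying measurement bears on what lies behind this difference.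

The bromine and the hydroxy enter together in compound 4, so the compounds shown leave open what each contributes alone. They also leave open how an amine or a carboxylic acid in place of the hydroxy, or a cyclohexyl in place of the whole phenyl ring, would read in this assay at this position.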